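The source may report more compounds than this note shows. Statements on the series, on what has been measured and on what is new or still open speak of the compounds shown alone.

In an ADME assay on Vero cells (Chlorocebus sabaeus) for cytotoxicity, read by MTT assay, with a stated time of 72 h (on this read-out lower numbers stand for higher toxicity in this test and higher numbers for lower toxicity in this test), each of the three measured compounds gave only a limit of the test, not a number:

compound 1, `COC(=O)c1cc(-c2cccc(NC(=O)c3ccc(/C=C/C(=O)c4cccc(C(F)(F)F)c4)cc3)c2)on1`: > 20 ug/mL
compound 2, `COC(=O)c1cc(-c2cccc(NC(=O)c3ccc(/C=C/C(=O)c4ccc(C)cc4)cc3)c2)on1`: > 80 ug/mL
compound 3, `COC(=O)c1cc(-c2cccc(NC(=O)c3ccc(/C=C/C(=O)c4ccc(OC)cc4)cc3)c2)on1`: > 10 ug/mL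

Compound 3 sits at the limit (the limit of > 10 ug/mL in this assay, at which 1 of the 3 values shown sits). Compound 1 sits at the limit (the limit of > 20 ug/mL in this assay, at which 1 of the 3 values shown sits). Compound 2 sits at the limit (the limit of > 80 ug/mL in this assay, at which 1 of the 3 values shown sits). Because all three values are limits, the steps a step that the two limits leave unreadable from compound 1 to compound 2, a step that the two limits leave unreadable from compound 1 to compound 3 and a step that the two limits leave unreadable from compound 2 to compound 3 cannot be read, neither in size nor in direction.

Compound 4, `COC(=O)c1cc(-c2cccc(NC(=O)c3ccc(/C=C/C(=O)c4ccc(C)c(F)c4)cc3)c2)on1`, differs from compound 3 in one place: 3-fluoro-4-methylphenyl in place of 4-methoxyphenyl on a carbonyl carbon. Among the compounds with values here, the steps that bear on this change are the exchange of the whole aryl group on the carbonyl carbon, a step that the two limits leave unreadable from compound 1 to compound 3, and the exchange of methoxy for methyl, a step that the two limits leave unreadable from compound 2 to compound 3; both are unreadable, so no step size can be carried over. Since none of the three compounds reached a measurable value in this assay, compound 4 is expected to be likewise weakly toxic, with a step that the limit leaves unreadable from compound 3 to compound 4 not beyond the scatter. The estimate for compound 4 is 40 ug/mL, in the range 12 ug/mL to 120 ug/mL.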

Compound 4, half-maximal cytotoxic concentration: > 50 ug/mL
Compound 4 ended at the assay's limit (the forecaster's own chance of this, stated with the estimate: 70%); middle value at least 1.2-fold (0.09 log units) away from the limit.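

Compound 4 gives > 50 ug/mL, which is a limit and not a number. The steps to compound 4 from compound 1, compound 2 and compound 3 cannot be read, in size or in direction. The compounds shown leave open where any of the four has its actual half-maximal cytotoxic concentration in this assay.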